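The source may hold more compounds than are shown below. What is called first, only, known or untested is meant among the compounds shown, and "the series" means these compounds.

Compound 1 `CCOc1ccc(Br)cc1C(C)NC(=O)NS(=O)(=O)c1ccccc1` gives > 300000 nM
Compound 2 `CC(NC(=O)NS(=O)(=O)c1ccccc1)c1cc(Br)ccc1OCc1ccccc1` gives 130000 nM
Compound 3 `Cc1ccc(S(=O)(=O)NC(=O)NC(C)c2cc(Br)ccc2OCc2ccccc2)cc1` gives 138000 nM

All three values come from a functional assay on thoracic aorta (Rattus norvegicus, strain Wistar), with a stated time of 15 min (on this read-out lower numbers stand for an effect already at smaller amounts and higher numbers for an effect only at larger amounts of compound), and were read the same way. The value of compound 1 is a limit of the assay and not a number. Compound 2 gives 130000 nM and stands level with compound 3 within the scatter, as a 1.1-fold higher number from compound 2 to compound 3 (0.03 log units; within the scatter) shows.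

Compound 4 `Cc1ccc(OCc2ccccc2)c(C(C)NC(=O)NS(=O)(=O)c2ccccc2)c1` has not been measured. Going by the values given here, its single change against compound 2 is methyl in place of bromo on an aromatic carbon in words, methyl in place of bromo on an aromatic carbon, para to a benzyloxy group.

Among the compounds with values here, no measured step replaces the bromo, so the evidence is indirect. Phenyl in place of methyl on a saturated chain carbon bound to an oxygen on an aromatic ring gave an at least 2.3-fold lower number from compound 1 to compound 2 (0.36 log units; beyond the scatter) and concerns a different place in the molecule. Within the data shown here, the only measured methyl change, methyl in place of hydrogen on an aromatic carbon, gave a 1.1-fold higher number from compound 2 to compound 3 (0.03 log units; within the scatter) and offers the closer guide.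

On that basis, the expected change in this assay is a 1.1-fold higher number from compound 2 to compound 4 (0.03 log units; within the scatter) and is estimated to stay within the scatter, with no firm direction. For compound 4 the estimated value is 140000 nM with an expected range from 60000 nM to 300000 nM as its bounds.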

Compound 4, half-maximal effective concentration: > 200000 nM
Compound 4 was reported as a limit; the forecaster's own chance of this, stated with the estimate: 25%; middle value at least 1.4-fold (0.15 log units) from the limit.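

Compound 4 is reported as a limit of the assay and not a number: the limit of > 200000 nM in this assay, at which 1 of the 4 values shown sits.

In this assay, going by these compounds alone, methyl in place of bromo, para to a benzyloxy group, gives an at least 1.5-fold higher number from compound 2 to compound 4 (0.18 log units; that floor lies within the scatter) and is the first direct read at this position, since the earlier steps concerned other places in the molecule. That read has one firm side: the change brings no lower number than that of compound 2, so methyl gives no gain over bromo here, yet the floor of the step lies within the scatter, so a real loss is not established. The methyl step elsewhere in the molecule, a 1.1-fold higher number from compound 2 to compound 3 (0.03 log units; within the scatter), therefore gives no guide to this position, where the change replaces bromo and not hydrogen.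

The compounds shown leave open the true size of the step and whether the position tolerates change in general or favours bromo in particular. Chloro, methoxy or an amine in the place of the bromo would separate these readings, each set against compound 2 with the benzyloxy group kept.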